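Swapping bromine for fluorine on a naphthyloxyacetohydrazone

This account rests on a few compounds, and the source may have more. Where it says the series, first, only, none or still open, it means among the compounds named here.

Measured so far:
Compound 1, `O=C(COc1cccc2ccccc12)N/N=C/c1ccc(O)cc1`: 3.73
Compound 2, `O=C(COc1cccc2ccccc12)N/N=C/C=C/c1ccccc1`: 4.43
Compound 3, `O=C(COc1cccc2ccccc12)N/N=C/c1cccc(Br)c1`: 4.81

Three hydrazones sharing one core have been measured in a physicochemical assay for lipophilicity, measured as octanol-water partition; on this read-out lower numbers stand for lower lipophilicity and higher numbers for higher lipophilicity. Compound 3 stands highest of the three: the step of a number 0.38 log units higher from compound 2 to compound 3 (beyond the scatter) and the step of a number 1.08 log units higher from compound 1 to compound 3 (beyond the scatter) are both beyond the scatter, so compound 3 is the most lipophilic of the set. Compound 4, `O=C(COc1cccc2ccccc12)N/N=C/c1ccc(F)cc1`, has not yet been measured. It differs from compound 3 in one place: 4-fluorophenyl in place of 3-bromophenyl on a carbon with a double bond to nitrogen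

Among the measured compounds shown here, no measured step exchanges one halogen for another, so no step bears directly on this change. What the measured steps do show is that the group on the carbon with a double bond to nitrogen moves this assay by modest to large amounts, as in a number 1.08 log units higher from compound 1 to compound 3 (beyond the scatter) and a number 0.70 log units higher from compound 1 to compound 2 (beyond the scatter). For compound 4 a modest decrease is expected, since every measured variation at this position shifted the read-out beyond the scatter and compound 3 sits at the top. The expected step is a number 0.56 log units lower from compound 3 to compound 4 (beyond the scatter), and compound 4 is estimated at 4.25, with a range from 3.85 to 4.65.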

Compound 4, partition coefficient: 4.16
Compound 4: the middle estimate sits 0.09 log units above what was measured; measured number inside the range.
By their numbers in this assay, from the lowest: compound 1; then compounds 4 and 2 (each within the scatter of the next); then compound 3.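

In this assay the exchange of 3-bromophenyl for 4-fluorophenyl on the carbon with a double bond to nitrogen gives a number 0.65 log units lower from compound 3 to compound 4 (beyond the scatter) and so shows that this position can move the read-out even when one halogen-bearing phenyl group replaces another. Fluoro in place of hydroxy on an aromatic carbon gives a number 0.43 log units higher from compound 1 to compound 4 (beyond the scatter) while 4-fluorophenyl in place of 2-phenylethenyl gives a number 0.27 log units lower from compound 2 to compound 4 (within the scatter) and leaves those two compounds unseparated. No measurement is available that would explain these shifts.

The halogen and its printed ring position change together between compound 3 and compound 4. The compounds shown cannot divide the step between those two changes. They also leave open how a phenyl group carrying an amine or a carboxylic acid would read in this assay at this position.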